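Swapping a Phenyl Tail for a Dichlorophenoxy Tail

The source may report more compounds than this note shows. Statements on the series, on what has been measured and on what is new or still open speak of the compounds shown alone.

Compound 1 `CC1CC(=O)N(c2ccccc2C(=O)OCC2CCCN(CCCCCc3ccccc3)C2)C1=O` is the most potent of the three measured compounds: in an in vitro functional assay on HEK ts201 cells for antagonist activity at Neuronal acetylcholine receptor; alpha3/beta4 (Homo sapiens), read by fluorescence and calcium flux (a lower number here means a stronger inhibitor, a higher number a weaker inhibitor), compound 1 gives 4170 nM. Compound 3 `C[C@H]1CC(=O)N(c2ccccc2C(=O)OC[C@H]2CCCN(CCCc3ccccc3)C2)C1=O` gives 11000 nM, and compound 2 `O=C(Nc1cccc2ccccc12)c1ccccc1-c1ccccc1` gives 18200 nM; both gaps from compound 1 lie beyond the scatter. Compound 4 `CC1CC(=O)N(c2ccccc2C(=O)OCC2CCCN(CCCCCOc3ccc(Cl)c(Cl)c3)C2)C1=O` differs from compound 1 in a single place: 3,4-dichlorophenoxy in place of phenyl on a saturated chain carbon, five bonds along the chain from an amine nitrogen in a ring. For the measured compounds named here, no pair of measured compounds shows this same change, so nothing measured here fixes the direction of the move from compound 1 to compound 4. A modest gain is expected, with the step of a 1.4-fold lower number from compound 1 to compound 4 (0.14 log units; within the scatter) likely small and possibly within the scatter. For compound 4 the expected value in this assay is 3000 nM, within a range from 800 nM to 12000 nM.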

Compound 4, half-maximal inhibitory concentration: 9120 nM
Beside the measured number, compound 4's estimate is 3.0-fold (0.48 log units) below it; the measured number falls inside the stated range.
By their numbers in this assay, from the lowest: compound 1; then compounds 4, 3 and 2 (each within the scatter of the next).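

In this assay, this swap gives a 2.2-fold higher number from compound 1 to compound 4 (0.34 log units; beyond the scatter), so at this place on the chain, 3,4-dichlorophenoxy is a modest loss rather than a gain over phenyl. The result shows that inhibition responds to what stands at the end of this chain. Nothing available explains why the number rises.

Still open, from the compounds shown here alone, is whether the oxygen or the two chlorine atoms account for this step, which a plain phenoxy tail could help separate. A single chlorine on the same tail could likewise show whether one such atom gives the same step.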